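Swapping the pyridine arm of compound 1 for a trifluorophenyl

The source may hold more compounds than are shown below. What is called first, only, known or untested is meant among the compounds shown, and "the series" means these compounds.

Compound 1 `CC1(C)CC(=O)C2=C(C1)NC(c1cccnc1)=NC2c1ccc(F)cc1Cl` is the weaker of the two compounds measured in an ADME assay on HepG2 2.2.15 cells (Homo sapiens) for cytotoxicity; on this read-out lower numbers stand for stronger inhibition and higher numbers for weaker inhibition: compound 1 gives 624000 nM, while compound 2 `CC1(C)CC(=O)C2=C(C1)NC(c1cccnc1)=NC2c1ccccc1` gives 173000 nM, a change of a 3.6-fold lower number from compound 1 to compound 2 (0.56 log units; beyond the scatter). Compound 3 `CC1(C)CC(=O)C2=C(C1)NC(c1c(F)cc(F)cc1F)=NC2c1ccc(F)cc1Cl` differs from compound 1 only by 2,4,6-trifluorophenyl in place of pyridin-3-yl on a carbon with a double bond to nitrogen. Among the measured compounds shown here, no measured step touches that position, so the size of the change is estimated from the shared core alone, and only a small shift is expected, if any. Compound 3 is expected near 400000 nM, within 150000 nM to 1000000 nM, a step of a 1.6-fold lower number from compound 1 to compound 3 (0.19 log units; within the scatter).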

Compound 3, half-maximal inhibitory concentration: 5600 nM
Compound 3: middle estimate off by 71-fold (1.85 log units), on the high side, outside the stated range (below it).
By their numbers in this assay, from the lowest: compound 3; then compound 2; then compound 1.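

In this assay, the carbon with a double bond to nitrogen proves a highly sensitive position: 2,4,6-trifluorophenyl in place of pyridin-3-yl gives a 110-fold lower number from compound 1 to compound 3 (2.05 log units; beyond the scatter), a larger change than the one on the saturated ring carbon, a 3.6-fold lower number from compound 1 to compound 2 (0.56 log units; beyond the scatter). Nothing available explains why this swap has so large an effect.

On these data alone, it remains open whether the three fluorines or the removal of the pyridine nitrogen accounts for the change. A plain phenyl group at this carbon would help separate the two.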